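Removing a methyl from the amide-bound aryl group

The source may report more compounds than this note shows. Statements on the series, on what has been measured and on what is new or still open speak of the compounds shown alone.

Compound 1, `O=C(CSc1snnc1-c1ccc(Br)cc1Br)Nc1ccccc1F`, in an ADME assay on MT4 cells (Homo sapiens) for cytotoxicity, read by MTT assay, with a stated time of 5 days (on this read-out higher numbers stand for lower toxicity in this test and lower numbers for higher toxicity in this test), gives >= 27800 nM, a limit of the assay.
Compound 2, `O=C(CSc1snnc1-c1ccc(Br)cc1Br)Nc1ccc(Cl)cc1`, in this assay gives 23300 nM.
Compound 3, `Cc1ccc(NC(=O)CSc2snnc2-c2ccc(Br)cc2Br)c(Br)c1`, in this assay gives > 216000 nM, a limit of the assay.

Compound 3 stands only as a limit, at the higher end of the three values. Compound 4, `O=C(CSc1snnc1-c1ccc(Br)cc1Br)Nc1ccccc1Br`, differs from it by hydrogen in place of methyl on an aromatic carbon. Within the data shown here, the steps that bear on this are an at least 9.2-fold higher number from compound 2 to compound 3 (0.96 log units; beyond the scatter) and a step that the two limits leave unreadable from compound 1 to compound 3, while an at least 1.1-fold lower number from compound 1 to compound 2 (0.07 log units; that floor lies within the scatter). Compound 1 also carries a single halogen on this aryl group and sits at a limit, so a number near or beyond the upper limit is expected for compound 4, giving an estimated at least 2.1-fold lower number from compound 3 to compound 4 (0.33 log units; beyond the scatter). Compound 4 is expected at 100000 nM, within 25000 nM to 300000 nM.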

Compound 4, half-maximal cytotoxic concentration: > 221000 nM
Compound 4: no number, only a limit; the forecaster's own chance of this, stated with the estimate: 60%; at least 2.2-fold (0.34 log units) between middle value and limit.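

Without the methyl, compound 4 again gives only a limit in this assay: the limit of > 221000 nM in this assay, at which 1 of the 4 values shown sits. The methyl is therefore not needed for a high number on this read-out, as the 2-bromophenyl group alone gives an at least 9.4-fold higher number from compound 2 to compound 4 (0.97 log units; beyond the scatter). The steps linking compound 4 to compound 3 and to compound 1 cannot be read, as each joins two limits.

On these data alone, whether the methyl changes the number at all stays open. So does how an amine or a carboxylic acid at that place would read.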